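Working notes: from compound 1 to compound 3

The source may report more compounds than this note shows. Statements on the series, on what has been measured and on what is new or still open speak of the compounds shown alone.

Values measured so far in a physicochemical assay for lipophilicity, at pH 7.4 (on this read-out higher numbers stand for higher lipophilicity and lower numbers for lower lipophilicity), are these
- compound 1 `CCc1c(C)[nH]c2cc(OC)c(Cl)cc2c1=O` gives 2.43
- compound 2 `CCCCCCCCCc1c(C)[nH]c2cc(OC)c(Cl)cc2c1=O` gives 4.74

Of these two numbers, compound 1 holds the lower. Compound 3 `COc1cc2[nH]c(C)c(C3CCCCC3)c(=O)c2cc1Cl` is still unmeasured. Relative to compound 1 it carries cyclohexyl in place of ethyl on an aromatic carbon and is otherwise unchanged.

Within the data shown here, one measured step bears on this change, and only indirectly. The step of a number 2.31 log units higher from compound 1 to compound 2 (beyond the scatter) is large and comes from heptyl in place of hydrogen on a saturated chain carbon. It involves an open chain at a saturated carbon rather than a ring, so it guides direction more than size. Less carbon is added here than in that step, so a moderate upward step is expected in this assay and a smaller one than that. The expected step is a number 1.17 log units higher from compound 1 to compound 3 (beyond the scatter) by this estimate. Compound 3 is expected at 3.6 with a range from 3 to 4.2 as its estimated span.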

Compound 3, distribution coefficient: 3.04
Estimate against measurement, compound 3: 0.56 log units above; the measured number falls inside the stated range.
By their numbers in this assay, from the lowest: compound 1; then compound 3; then compound 2.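

In this assay the exchange of ethyl for cyclohexyl on this aromatic carbon gives a number 0.61 log units higher from compound 1 to compound 3 (beyond the scatter) and shows that a six-membered ring of carbon only at this place also moves the number upward, as the longer open chain of compound 2 did. Against the larger a number 2.31 log units higher from compound 1 to compound 2 (beyond the scatter) this step is small enough to place compound 3 between compound 1 and compound 2, so the order of the three follows the size of the group, though two changes at one place are too few to separate a ring from a chain. No supporting measurement bears on the size of this step.

Going by these compounds, whether hexyl on this aromatic carbon would stand near compound 3 or nearer compound 2 remains open. Also open, on these data alone, is how the number would respond to an amine or a carboxylic acid at this place.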